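Enantiomer swap at the ring stereocentre of compound 1

A few compounds are considered here, and "the series" means these few. Any claim that something is new, unique, unknown or untested is made for them only; others in the source may bear on it.

Compound 1 `COc1cc(NC(=O)[C@@H]2CSC(c3ccccc3)=N2)cc(OC)c1OC` is a trimethoxyphenyl amide of the thiazoline core. In a functional assay on PC-3 cells (Homo sapiens) for cytotoxicity, read by sulforhodamine B assay, with a stated time of 48 h (on this read-out higher numbers stand for weaker inhibition and lower numbers for stronger inhibition), compound 1 returns only a limit, > 20000 nM, so no number is known for it. This is the limit of > 20000 nM in this assay, at which 1 of the 2 values shown sits, and it places compound 1 at the weak end of what has been measured. For the measured compounds named here, the other measured member, compound 2 `CCCCCCCCCCCCCCCCNC(=O)[C@@H]1CSC(c2ccc(NC(C)=O)cc2)N1`, carries a long alkyl amide and a different aryl substituent; in this assay compound 2 gives 1200 nM, a finite value, but compound 2 is not a single-point neighbour of compound 1 and no step between them is drawn.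

Compound 3 `COc1cc(NC(=O)[C@H]2CSC(c3ccccc3)=N2)cc(OC)c1OC` is the next compound to be measured. Its difference from compound 1 is the two compounds have the same atoms and bonds and differ only in configuration as drawn: 1 of 1 stereo elements differ; a stereocentre at a saturated ring carbon is drawn R in compound 1 and S in compound 3. Without a measured step for this kind of change within the series, the expectation is that the step from compound 1 to compound 3 in this assay stays within the scatter, with a fair chance that compound 3 also returns only a limit. On that basis compound 3 is estimated at 18000 nM, within 4000 nM to 60000 nM, and the implied step is an at least 1.1-fold lower number from compound 1 to compound 3 (0.04 log units; that floor lies within the scatter).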

Compound 3, half-maximal inhibitory concentration: 13200 nM
Beside the measured number, compound 3's estimate is 1.4-fold (0.13 log units) above it; the measured number falls inside the stated range.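

For the compounds shown here, the change of the saturated ring carbon from R to S reads in this assay as an at least 1.5-fold lower number from compound 1 to compound 3 (0.18 log units; that floor lies within the scatter), the first step at this stereocentre. Compound 1 stands at a limit and not at a number, so this step has a floor and no upper end, because one of its two ends rests on that limit: the limit of > 20000 nM in this assay, at which 1 of the 3 values shown sits. Whatever separates this pair can be assigned to the configuration at this one carbon and to no other part of the structure, because nothing else in the two structures changes: the fact that compounds 1 and 3 differ only in the configuration as drawn

On these data alone, what remains open is whether the configuration at this carbon counts for more or for less once the trimethoxyphenyl amide gives way to an amide with a shorter alkyl chain, or once the phenyl on the core carries an amine or a carboxylic acid. As far as these compounds go, the true size of the step for this pair also remains unknown, with no number for compound 1, so it is not settled whether the two configurations differ beyond the scatter.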